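The source may hold more compounds than are shown below. What is called first, only, known or untested is meant among the compounds shown, and "the series" means these compounds.

Among the measured compounds shown here, in a functional assay on cells (Neutrophil, Homo sapiens) for inhibition, with a stated time of 10 min (on this read-out higher numbers stand for weaker inhibition and lower numbers for stronger inhibition), compound 1 (`CCOC(=O)c1cnn(CC(C)O)c1NC(=O)NCc1ccccc1`) gives 0.00054 nM as its reading, the lowest number among the three compounds measured so far. Compound 3 (`CCOC(=O)c1cnn(CC(O)CC)c1NC(=O)Nc1ccccc1F`) lies nearest with 0.0016 nM on the same read-out, and compound 2 (`CCOC(=O)c1cnn(CC(O)CC)c1NC(=O)Nc1cccc2ccccc12`) lies furthest with 9.6 nM on it. Both gaps from compound 1 are beyond the usual scatter. No two of these three compounds differ in one place alone, and the data hold no clean single change to reason from.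

The next compound is compound 4 (`CCOC(=O)c1cnn(CC(C)O)c1NC(=O)NC(C)C`), which has not yet been measured. It puts isopropyl in place of benzyl on an amide-type nitrogen, and the change counts out as isopropyl in place of benzyl on an amide-type nitrogen in full. For the measured compounds named here, all three measured compounds carry an aromatic ring on that nitrogen, whereas compound 4 has no ring there, and nothing measured so far shows what such a compound does. A higher number, meaning weaker inhibition, is expected, with a wide margin: compound 1 at 0.00054 nM and compound 2 at 9.6 nM lie far apart. The estimated step is a 37-fold higher number from compound 1 to compound 4 (1.57 log units; beyond the scatter) toward weaker inhibition. For compound 4 the estimated value is 0.02 nM within a range of 0.0008 nM to 3 nM in this assay as the expected reading.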

Compound 4, half-maximal inhibitory concentration: 0.00082 nM
For compound 4 the middle estimate is 24-fold (1.39 log units) above the measured one; measured number inside the range.
By their numbers in this assay, from the lowest: compounds 1, 4 and 3 (each within the scatter of the next, the first and the last beyond it); then compound 2.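

In this assay, among the compounds shown here, the step of a 1.5-fold higher number from compound 1 to compound 4 (0.18 log units; within the scatter) lies within the scatter, so this is the first pair that isolates the group on the amide-type nitrogen whose other neighbour is the carbonyl carbon. Benzyl, with 7 heavy atoms and one six-membered aromatic ring of carbon only, gives way to isopropyl, with 3 heavy atoms and no ring, and the two readings cannot be told apart, so at this position and on the core of compound 1 an aromatic ring is not needed for a reading at this level. No measurement shown explains why the two groups read alike.

Going by these compounds, it remains open whether a longer chain such as n-hexyl, a cyclohexyl group, or a chain ending in an amine or a carboxylic acid on that nitrogen would read alike in this assay. A single pair also cannot show whether isopropyl in place of benzyl would give the same result on compounds whose other parts differ, as those of compound 2 and compound 3 do.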